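The source may report more compounds than this note shows. Statements on the series, on what has been measured and on what is new or still open speak of the compounds shown alone.

In an ADME assay on HUVEC cells (Homo sapiens) for antiproliferative activity, read by MTT assay, with a stated time of 48 h (on this read-out higher numbers stand for weaker inhibition and lower numbers for stronger inhibition), three compounds of one shared core have been measured so far.

Compound 1 `Cc1ccccc1-n1nncc1CN1C(=O)C2(C(C#N)=C(N)Oc3c(N)cc4nc5ccccc5nc4c32)c2ccccc21` reaches only a limit of the assay, > 50000 nM.
Compound 2 `N#CC1=C(N)Oc2c(N)cc3nc4ccccc4nc3c2C12C(=O)N(Cc1cnnn1-c1ccccc1Br)c1ccccc12` gives 34200 nM.
Compound 3 `N#CC1=C(N)Oc2c(N)cc3nc4ccccc4nc3c2C12C(=O)N(Cc1cnnn1-c1cccc(C(F)(F)F)c1)c1ccccc12` likewise reaches only a limit of the assay, > 50000 nM.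

Compound 3 thus stands at the limit of > 50000 nM in this assay, at which 2 of the 3 values shown sit. The steps that swap the aryl group on the aromatic nitrogen give little to read: an at least 1.4-fold higher number from compound 2 to compound 3 (0.16 log units; that floor lies within the scatter), and a step that the two limits leave unreadable from compound 1 to compound 3. The remaining step, an at least 1.4-fold lower number from compound 1 to compound 2 (0.16 log units; that floor lies within the scatter), is also no larger than its floor. All three values describe weak inhibition.

Compound 4 `CCOc1ccc(-n2nncc2CN2C(=O)C3(C(C#N)=C(N)Oc4c(N)cc5nc6ccccc6nc5c43)c3ccccc32)cc1` differs from compound 3 in one place: 4-ethoxyphenyl in place of 3-(trifluoromethyl)phenyl on an aromatic nitrogen. The measured swaps at this same aromatic nitrogen bear on this change, and none of them produced a step that can be called larger than the scatter. A step of no readable size is therefore expected, a number no higher from compound 3 to compound 4 (the limit leaves the size open), with compound 4 most likely remaining at or near the limit of this assay. The estimate for compound 4 is 50000 nM, expected to lie between 20000 nM and 120000 nM.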

Compound 4, half-maximal inhibitory concentration: > 50000 nM
Compound 4 was reported as a limit; the forecaster's own chance of this, stated with the estimate: 60%; the middle value sits exactly at the limit.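

The 4-ethoxyphenyl group counts one hydrogen-bond acceptor where 3-(trifluoromethyl)phenyl counts none, yet on this aromatic nitrogen it does not bring compound 4 off the limit of this assay. Going by these compounds alone, the only step from the new compound that has a readable floor is an at least 1.4-fold higher number from compound 2 to compound 4 (0.16 log units; that floor lies within the scatter), and the other steps to it cannot be read, with a limit at both ends. A third aryl group at this position thus ends at the same limit: the limit of > 50000 nM in this assay, at which 3 of the 4 values shown sit.

The compounds shown leave open whether a phenyl ring carrying an amine or a carboxylic acid on this aromatic nitrogen would give a number clearly away from that limit. They also leave open how compound 1, compound 3 and compound 4 rank among themselves.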